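Ester in place of carbonate on a prodrug side chain

The source may hold more compounds than are shown below. What is called first, only, known or untested is meant among the compounds shown, and "the series" means these compounds.

Compound 1 `CC(C)OC(=O)OCOC(=O)C1=C(S[C@@H]2CN[C@H](C(=O)Nc3cccc(C(=O)O)c3)C2)[C@H](C)[C@@H]2[C@@H]([C@@H](C)O)C(=O)N12` gives > 95% in a physicochemical assay for metabolic stability, read by LC-MS, in phosphate buffer, with a stated time of 3 h, at pH 7.4, tested at 50 uM (on this read-out lower numbers stand for a less stable compound and higher numbers for a more stable compound), which is a limit of the assay and not a number. Compound 2 `CC(C)OC(=O)OCOC(=O)C1=C(S[C@@H]2CN[C@H](C(=O)Nc3cccc(C(=O)OCOC(=O)OC(C)C)c3)C2)[C@H](C)[C@@H]2[C@@H]([C@@H](C)O)C(=O)N12` gives > 95%, also a limit. Among the compounds with values here, the only measured step, a step that the two limits leave unreadable from compound 1 to compound 2, therefore cannot be read in size, and the shared ground of both values is the limit of > 95% in this assay, at which 2 of the 2 values shown sit. Compound 1 thus stands at the high end of what this assay can report, with no number above it.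

Compound 3 `CC(C)C(=O)OCOC(=O)C1=C(S[C@@H]2CN[C@H](C(=O)Nc3cccc(C(=O)O)c3)C2)[C@H](C)[C@@H]2[C@@H]([C@@H](C)O)C(=O)N12` differs from compound 1 by isopropyl in place of isopropoxy on a carbonyl carbon. No measured step bears directly on this change, since the one step shown is unreadable. Compound 3 is expected to stay close to the limit in this assay, and its step of a number at least 2 percentage points lower from compound 1 to compound 3 (that floor lies within the scatter) is expected to be none beyond the scatter. The estimate for compound 3 is 93%, within a range from 80% to 99%.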

Compound 3, percent of the compound remaining: > 95%
Compound 3: a limit, no number; the forecaster's own chance of this, stated with the estimate: 65%; at least 2 percentage points between middle value and limit.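

In this assay compound 3 gives > 95%, a limit of the assay and not a number. The step from compound 1 to compound 3 therefore cannot be read, and all values shown sit at the same limit: the limit of > 95% in this assay, at which 3 of the 3 values shown sit. Going by these compounds, how compound 1, compound 2 and compound 3 truly rank in stability stays open.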